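Three Inactive Analogues and a Propyl Homologue to Come

This account rests on a few compounds, and the source may have more. Where it says the series, first, only, none or still open, it means among the compounds named here.

Compound 1 `C=CCn1ncc2c(CC)ncn2c1=O`, compound 2 `CCc1nc(C)c2cnnc(SC)n12` and compound 3 `CCCc1nc(C)c2cnnc(SC)n12` were all tested in a functional assay for inhibition, with Homo sapiens as the target; a higher number here means a weaker inhibitor, a lower number a stronger inhibitor. In this assay compound 1 gives > 48000 nM, which is a limit of the assay and not a number. Compound 2 gives > 48000 nM in this assay, again a limit. Compound 3 gives > 48000 nM in this assay, a limit as well. Compound 3 differs from compound 2 by methyl in place of hydrogen on a saturated chain carbon, two bonds along the chain from an aromatic carbon, and the step that the two limits leave unreadable from compound 2 to compound 3 cannot be sized because of the limit of > 48000 nM in this assay, at which 3 of the 3 values shown sit. The difference between the core of compound 1 and the core of compound 2 is not broken down here. Compound 4 `C=CCn1ncc2c(CCC)ncn2c1=O` has not been measured; it differs from compound 1 by methyl in place of hydrogen on a saturated chain carbon, two bonds along the chain from an aromatic carbon, the same change as that from compound 2 to compound 3. The expected step is a step that the limit leaves unreadable from compound 1 to compound 4, an expectation that rests on compound 1 having given > 48000 nM in this assay. Compound 4 is therefore estimated at 60000 nM, most likely between 20000 nM and 200000 nM, and quite probably again only a limit.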

Compound 4, half-maximal inhibitory concentration: > 48000 nM
Compound 4 gave a limit, no number; the forecaster's own chance of this, stated with the estimate: 85%; the middle value is on the limit's open side.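

In this assay compound 4 gives > 48000 nM, which is a limit of the assay and not a number. Among these compounds, no step from compound 1 to compound 4 can be read because both values are limits: the limit of > 48000 nM in this assay, at which 4 of the 4 values shown sit. The compounds shown leave open whether either the core or the chain length affects inhibition in this assay.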